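Swapping a Ring for a Branched Chain on the Urea

A few compounds are considered here, and "the series" means these few. Any claim that something is new, unique, unknown or untested is made for them only; others in the source may bear on it.

In a functional assay on the whole organism (strain Sprague-Dawley) for inhibition, with Rattus norvegicus as the target, read by paw edema, with stated times of 30 min and 1 h, at a dose of 80 mg/kg by the oral route (on this read-out lower numbers stand for less inhibition and higher numbers for more inhibition at the one dose given (going by the name of the read-out)), compound 1 `Cc1nc2ccccc2c(=O)n1NC(=O)NC1CCCCC1` gives 12%. Compound 2 `O=c1c2ccccc2nc(CO[N+](=O)[O-])n1NS(=O)(=O)c1ccccc1` gives in this assay 2.4%. Compound 1 has the higher of the two numbers, but the gap to compound 2 lies within the scatter of repeated measurements, so the two results read as the same. Both are small numbers on a read-out where a higher number means more inhibition.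

Compound 3 `Cc1nc2ccccc2c(=O)n1NC(=O)NC(C)(C)C` has not been measured yet. It differs from compound 1 in one place: tert-butyl in place of cyclohexyl on an amide-type nitrogen. For the measured compounds named here, no step between two measured compounds that differ in a single place is available here, so there is nothing to compare this change against directly. Since compound 1 sits at 12%, a low number, the expectation for compound 3 is a move within the scatter and in no particular direction. Compound 3 is therefore estimated at 10%, with a range from 0% to 22%. This estimate means an expected step of a number 2 percentage points lower from compound 1 to compound 3 (within the scatter), which lies within the scatter.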

Compound 3, a percentage reported as inhibition, in the whole organism at one dose (the size of the read-out at that dose, not a potency): 10.4%
Estimate against measurement, compound 3: 0.4 percentage points below; low and high end bracket the measured number.
By their numbers in this assay, from the lowest: compounds 2, 3 and 1 (each within the scatter of the next).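

In this assay, for the compounds shown here, tert-butyl in place of cyclohexyl on an amide-type nitrogen gives a number 1.6 percentage points lower from compound 1 to compound 3 (within the scatter) and offers the first direct look at a single change at this position. The six-membered carbon ring can therefore give way to a branched chain with fewer carbon atoms and no ring, and the two results still read as the same. At this one oral dose, the ring is thus not needed to keep the number where compound 1 has it, although the swap brings no clear gain either; no measurement of a property of these two groups bears on this result.

Cyclohexyl and tert-butyl are both made of carbon only and have no hydrogen-bond donors or acceptors, so the comparison covers only a narrow kind of change at this nitrogen. Going by these compounds, whether a phenyl ring, a longer chain such as n-hexyl, or a chain ending in an amine or a carboxylic acid would move the number beyond the scatter remains open.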